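From Two Phenyl Groups to One

The source may hold more compounds than are shown below. What is called first, only, known or untested is meant among the compounds shown, and "the series" means these compounds.

Of the compounds shown here, three have so far been tested in a functional assay on L1210 cells (Mus musculus) for inhibition; a higher number here means a weaker inhibitor, a lower number a stronger inhibitor. Compound 1 (`CCC(C)C1NC(=O)N(C2CCCCC2)C1=O`) reads > 200000 nM, which is a limit of the assay and not a number. Compound 3 (`CC(C)C(NC(=O)NO)C(=O)NC1CCCC1`) reads > 200000 nM, which is likewise a limit. Going by the values given here, compound 2 (`CCC(C)C(NC(=O)n1nnc2ccccc21)C(=O)NC(c1ccccc1)c1ccccc1`) gives 17000 nM, the only actual number available in this assay, and so the sole numerical reference point.

Compound 4 (`CCC(C)C(NC(=O)n1nnc2ccccc21)C(=O)NCc1ccccc1`) has not yet been measured. It differs from compound 2 in one place: hydrogen in place of phenyl on a saturated chain carbon bound to an amide-type nitrogen and an aromatic carbon. The change is hydrogen in place of phenyl on a saturated chain carbon bound to an amide-type nitrogen and an aromatic carbon.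

Among the compounds with values here, no measured pair shows what a change of this kind does, so the expectation starts from compound 2 at 17000 nM and carries wide uncertainty. A moderate move towards weaker inhibition is expected in this assay, probably somewhat beyond the usual scatter, and a result reported only as a limit remains possible. The expected change is a 2.6-fold higher number from compound 2 to compound 4 (0.42 log units; beyond the scatter). For compound 4 the estimated value is 45000 nM, with an expected range from 15000 nM to 150000 nM.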

Compound 4, half-maximal inhibitory concentration: 123000 nM
For compound 4 the middle estimate is 2.7-fold (0.44 log units) below the measured one, and the stated range covers the measured number.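

In this assay, replacing one phenyl with hydrogen on the saturated chain carbon bound to an amide-type nitrogen and an aromatic carbon gives a 7.2-fold higher number from compound 2 to compound 4 (0.86 log units; beyond the scatter), a modest step and the first in this set that can be read as a difference between two numbers. It shows that this position is sensitive to the change: inhibition is weaker with one phenyl on that carbon than with two, although compound 4 still gives a number, 123000 nM, and not a limit. Compound 4 now sits close to the top of what the read-out can express, so little room remains for reading further weakening at this position as a number: the limit of > 200000 nM in this assay, at which 2 of the 4 values shown sit.

Going by these compounds alone, the single step cannot tell whether the second phenyl itself matters or whether any group of carbon atoms on that carbon would do; a methyl or a cyclohexyl there would separate these two readings. From the compounds shown here alone, compounds 1 and 3 differ from the others in more than one place, so they cannot be compared with them, and what the rest of the shared core contributes stays open.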